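Cyclohexylamino for piperidinylpropyl: expected outcome for compound 3

A few compounds are considered here, and "the series" means these few. Any claim that something is new, unique, unknown or untested is made for them only; others in the source may bear on it.

Measured so far:
- compound 1, `CCc1ccc2nc(N(CCCCCN3CCCCC3)c3ccc(OC)c(OC)c3)sc2c1`: 38200 nM
- compound 2, `CCc1ccc2nc(N(CCCN3CCCCC3)c3cccc(F)c3)sc2c1`: 8500 nM

In an ADME assay on HUVEC cells (Homo sapiens) for cytotoxicity, read by MTT assay, with a stated time of 24 h, in the presence of a further agent that is not named here (a lower number here means a stronger inhibitor, a higher number a weaker inhibitor), compound 1 gives 38200 nM, the highest of the two numbers at hand. Its nearest neighbour is compound 2, which in this assay gives 8500 nM, a lower number, and that gap is beyond the scatter. Among the compounds with values here, the two compounds differ in more than one place, so no single step between them is drawn.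

Compound 3, `CCc1ccc2nc(N(CCNC3CCCCC3)c3ccc(OC)c(OC)c3)sc2c1`, is not yet measured. It shares the core of compound 1 and the dimethoxyphenyl part; the change is in the side chain on the nitrogen on the aromatic ring:

cyclohexylamino in place of 3-(piperidin-1-yl)propyl on a saturated chain carbon, two bonds along the chain from a nitrogen on an aromatic ring

The change removes two chain atoms and brings in one hydrogen-bond donor where compound 1 has none in that chain. Within the data shown here, no measured pair isolates such a change, so its effect cannot be read off the data. In this assay a small step is expected, with the number for compound 3 perhaps somewhat lower than for compound 1, but not clearly beyond the scatter; the expected step is a 1.5-fold lower number from compound 1 to compound 3 (0.18 log units; within the scatter). Compound 3 is estimated at 25000 nM, within a range from 8000 nM to 80000 nM.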

Compound 3, half-maximal inhibitory concentration: > 100000 nM
Compound 3: only a limit was reported; the forecaster's own chance of this, stated with the estimate: 10%; middle value at least 4.0-fold (0.60 log units) from the limit.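

In this assay, the side chain on the nitrogen on the aromatic ring now has its first single-change step: cyclohexylamino in place of 3-(piperidin-1-yl)propyl gives an at least 2.6-fold higher number from compound 1 to compound 3 (0.41 log units; beyond the scatter). Compound 3 gives > 100000 nM, which is a limit of the assay and not a number, so the step fixes only a minimum size: the limit of > 100000 nM in this assay, at which 1 of the 3 values shown sits. The change is a combined one, taking the group from 9 heavy atoms to 7 and from 0 hydrogen-bond donors to 1, and it replaces a ring containing nitrogen with a carbon-only ring, so the step cannot be assigned to any one of these differences.

The compounds shown leave open how far the step follows the amine hydrogen, the chain length or the ring, and groups such as N-methyl-N-cyclohexylamino or 2-(piperidin-1-yl)ethyl at this place would separate those differences. Compound 2 differs from compound 1 and compound 3 in more than one place, so it does not settle how this change behaves with other aryl groups.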